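Removing a Chloro Group: Expected Clearance for Compound 3

The source may hold more compounds than are shown below. What is called first, only, known or untested is meant among the compounds shown, and "the series" means these compounds.

Going by the values given here, compound 1 `O=S(=O)(c1ccc(F)c(Cl)c1)c1cnc2cc(F)ccc2c1-c1ccc(Cl)cc1` is measured in an ADME assay on microsomes from liver (Homo sapiens) for metabolic stability, tested at 2.5 uM (a lower number here means slower removal, a higher number faster removal of the compound), and gives 0.39 mL/min, the lowest of the two numbers known. Compound 2 `O=S(=O)(c1ccc(F)c(Cl)c1)c1cnc2cc(F)ccc2c1-c1ccc(F)cc1` gives 0.69 mL/min in this assay, and the step of a 1.8-fold higher number from compound 1 to compound 2 (0.25 log units; within the scatter) lies within the scatter. Compound 3 `O=S(=O)(c1ccc(F)cc1)c1cnc2cc(F)ccc2c1-c1ccc(Cl)cc1` differs from compound 1 by hydrogen in place of chloro on an aromatic carbon, so that the 3-chloro-4-fluorophenyl becomes 4-fluorophenyl. Among the compounds with values here, the only measured step concerns a different ring and stays within the scatter, so for compound 3 no shift beyond the scatter is expected, an estimated 1.2-fold higher number from compound 1 to compound 3 (0.06 log units; within the scatter). Compound 3 is therefore expected to give 0.45 mL/min, within a range of 0.2 mL/min to 1 mL/min.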

Compound 3, intrinsic clearance in a liver preparation (reported as CLH), per the amount of preparation that the assay uses: 1.23 mL/min
Compound 3: middle estimate off by 2.7-fold (0.44 log units), on the low side; the whole stated range lies below it.
By their numbers in this assay, from the lowest: compounds 1, 2 and 3 (each within the scatter of the next, the first and the last beyond it).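

Going by these compounds alone, the change from 3-chloro-4-fluorophenyl to 4-fluorophenyl is the first single change here to go beyond the scatter in this assay (a 3.2-fold higher number from compound 1 to compound 3 (0.50 log units; beyond the scatter)). At this place, ortho to a fluoro group, having chloro rather than hydrogen therefore goes with slower removal, though the size of the step is modest. Nothing available explains this shift. At this place the compounds shown carry only chloro or hydrogen. On these data alone, how a methyl, a methoxy or an amine there would compare remains open, as does whether the step would repeat with other groups on the rest of the molecule.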